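The compounds below may be only part of what the source reports. "The series", "measured", "known", "first", "only" and "open" are said of these compounds alone.

For the measured compounds named here, compound 1 `Cn1cc(C(=O)N2CC3(C2)CN(c2cncc(N4C(=O)c5ccc(Cl)cc5C4(C)C)c2)C3)cn1` gives the lowest number of the three compounds measured so far: in an assay on cells for inhibition of cytochrome P450 11B2, mitochondrial (Homo sapiens), read by HTRF (a lower number here means a stronger inhibitor, a higher number a weaker inhibitor), compound 1 gives 2 nM. Its nearest neighbour is compound 3 `CCC(=O)N[C@@H]1CCCc2c1cncc2N1Cc2cc(Cl)ccc2C1=O`, which in this assay gives 28 nM; the two differ by a margin well beyond the scatter. Furthest away is compound 2 `CC(=O)N[C@H]1CCCc2c1cncc2N1Cc2cc(Cl)ccc2C1=O`, which in this assay gives 5140 nM. Going by the values given here, compounds 2 and 3 share a related core but differ in their amide chain and in stereochemistry, and no single-point step between them is at hand, so their two values are noted only as they stand.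

Compound 4 `CC(=O)N1CC2(C1)CN(c1cncc(N3C(=O)c4ccc(Cl)cc4C3(C)C)c1)C2` keeps the whole of compound 1 except at the amide carbonyl on the spirocyclic ring: methyl in place of 1-methyl-1H-pyrazol-4-yl on a carbonyl carbon. Among the compounds with values here, no measured pair shows exactly this change, so the step can only be expected. Since compound 1 gives 2 nM, and an aromatic ring is replaced by a single carbon at a position that appears to contribute to potency, the step from compound 1 to compound 4 in this assay is expected to be a loss, of moderate size, a 7.5-fold higher number from compound 1 to compound 4 (0.88 log units; beyond the scatter). Compound 4 is therefore estimated at 15 nM, with a range from 3 nM to 80 nM.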

Compound 4, half-maximal inhibitory concentration: 23 nM
For compound 4 the middle estimate is 1.5-fold (0.19 log units) below the measured one; low and high end bracket the measured number.
By their numbers in this assay, from the lowest: compound 1; then compounds 4 and 3 (each within the scatter of the next); then compound 2.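

In this assay, putting methyl in place of 1-methyl-1H-pyrazol-4-yl on the carbonyl carbon gives a 12-fold higher number from compound 1 to compound 4 (1.06 log units; beyond the scatter). For the compounds shown here, this is the first pair here that differs in one place only, so the gap can be tied to this single change, which the earlier compounds could not do. It shows that the group on this carbonyl carbon matters for inhibition, although compound 4 , with only methyl there, still gives 23 nM in the same assay. A five-membered aromatic ring with hydrogen-bond acceptors gives way to a single carbon, and nothing available explains which part of that difference accounts for the step.

The compounds shown leave open whether a different ring on this carbonyl carbon, such as phenyl, or the pyrazole without its methyl, would stay as close to compound 1 as the full group does. They also leave open whether a longer chain such as ethyl, or an amine such as dimethylamino, would fall nearer to compound 1 or to compound 4 .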